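This account rests on a few compounds, and the source may have more. Where it says the series, first, only, none or still open, it means among the compounds named here.

Series notes, an ADME assay on Huh-7 cells (Homo sapiens) for cytotoxicity, read by MTT assay, with a stated time of 48 h; a higher number here means a weaker inhibitor, a lower number a stronger inhibitor. Compound 1 `O=[N+]([O-])c1cc(CSc2nnnn2C2CCCCC2)cc([N+](=O)[O-])c1` returns only a limit, > 30000 nM. Compound 2 `O=[N+]([O-])c1cc(C[Se]c2nnnn2Cc2ccccc2)cc([N+](=O)[O-])c1` likewise returns a limit, > 30000 nM. Compound 3 `O=[N+]([O-])c1cc(C[Se]c2nnnn2C2CCCCC2)cc([N+](=O)[O-])c1` also returns a limit, > 30000 nM. Within the data shown here, compound 3 thus stands at the same limit as the two other values shown, and the one measured step, a step that the two limits leave unreadable from compound 2 to compound 3, cannot be sized because the limit of > 30000 nM in this assay, at which 3 of the 3 values shown sit, gathers every value so far. Compound 4 `COc1ccc(-n2nnnc2[Se]Cc2cc([N+](=O)[O-])cc([N+](=O)[O-])c2)cc1` differs from compound 3 by 4-methoxyphenyl in place of cyclohexyl on an aromatic nitrogen. Among the measured compounds shown here, no measured step resolves a size for this change; the only evidence is the limit of > 30000 nM in this assay, at which 3 of the 3 values shown sit, so no step beyond the scatter is expected in either direction, and a further limit is the likelier outcome. Compound 4 is therefore expected at 40000 nM, within 20000 nM to 100000 nM. The expected step in this assay is a step that the limit leaves unreadable from compound 3 to compound 4.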

Compound 4, half-maximal inhibitory concentration: > 30000 nM
Compound 4 was reported as a limit; the forecaster's own chance of this, stated with the estimate: 85%; the middle value does not contradict the limit.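

Among these compounds, compound 4 also returns only a limit in this assay, > 30000 nM, so no step from compound 2 or compound 3 to it can be read. The compounds shown leave open any difference among benzyl, cyclohexyl and 4-methoxyphenyl: the limit of > 30000 nM in this assay, at which 4 of the 4 values shown sit.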